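The compounds below may be only part of what the source reports. "The series", "measured", "known", "first", "only" and "open" are said of these compounds alone.

Of the compounds shown here, two of a shared core have been measured in an ADME assay on NCM460 cells (Homo sapiens) for cytotoxicity, read by MTT assay, with a stated time of 72 h; a lower number here means a stronger inhibitor, a higher number a weaker inhibitor. Compound 1 `CCCCCN1C(=O)C/C(=C\c2cccc(C(=O)Nc3ccc(C)cc3)c2)C1=O` is one of them. In this assay compound 1 reaches only the limit of the measurement, > 100000 nM. Compound 2 `CCCCCN1C(=O)C/C(=C\c2cccc(C(=O)Nc3cccc(CC)c3)c2)C1=O` is the other. In this assay compound 2 likewise stops at the limit, > 100000 nM. The step that the two limits leave unreadable from compound 1 to compound 2 therefore cannot be read, and on the numbers shown compound 2 stands at the limit with no figure of its own, as the evidence that the limit of > 100000 nM in this assay, at which 2 of the 2 values shown sit, makes plain.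

Compound 3 `CCCCCN1C(=O)C/C(=C\c2cccc(C(=O)NCCCC)c2)C1=O` is not yet measured. It differs from compound 2 by butyl in place of 3-ethylphenyl on an amide-type nitrogen. Among the measured compounds shown here, the only measured step, the one from compound 1 to compound 2, bears on this change merely as a change of the group on the amide-type nitrogen, and its size is not readable, so no step in this assay can be expected from it in either direction. Compound 3 is therefore expected to sit at the limit as well, estimated at 150000 nM within 100000 nM to 1000000 nM, which means an expected step that the limit leaves unreadable from compound 2 to compound 3.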

Compound 3, half-maximal inhibitory concentration: > 100000 nM
Compound 3: a limit, no number (the forecaster's own chance of this, stated with the estimate: 85%); the middle value lies beyond the limit too.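

No new step can be read in this assay, since compound 1, compound 2 and compound 3 all stop at a limit and give no number: the limit of > 100000 nM in this assay, at which 3 of the 3 values shown sit. The compounds shown leave open whether any group on the amide-type nitrogen of the shared core would give a readable value in this assay.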